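The source may hold more compounds than are shown below. What is called first, only, known or untested is meant among the compounds shown, and "the series" means these compounds.

In a functional assay with Homo sapiens as the target (on this read-out higher numbers stand for weaker inhibition and lower numbers for stronger inhibition), compound 1 `CC(C)[C@H](NC(=O)COc1cccc2ccccc12)C(=O)N[C@@H](CC(=O)O)C(=O)COc1ccccc1[N+](=O)[O-]` gives 27700 nM, compound 2 `CC(C)[C@H](NC(=O)COc1cccc2ccccc12)C(=O)N[C@@H](CC(=O)O)C(=O)COc1cccc(F)c1` gives 12000 nM and compound 3 `CC(C)[C@H](NC(=O)COc1cccc2ccccc12)C(=O)N[C@@H](CC(=O)O)C(=O)COc1ccc(F)cc1` gives 14300 nM, a value within the scatter of both others. Compound 4 `CC(C)[C@H](NC(=O)COc1cccc2ccccc12)C(=O)N[C@@H](CC(=O)O)C(=O)COc1cc(F)c(F)cc1F` carries one change from compound 3: 2,4,5-trifluorophenyl in place of 4-fluorophenyl on an oxygen on a saturated carbon, with 2,4,5-trifluorophenyl in place of 4-fluorophenyl on an oxygen on a saturated carbon. Three measured changes at this place bear on it: a 1.2-fold higher number from compound 2 to compound 3 (0.08 log units; within the scatter) and a 1.9-fold lower number from compound 1 to compound 3 (0.29 log units; within the scatter) stay within the scatter, while a 2.3-fold lower number from compound 1 to compound 2 (0.36 log units; beyond the scatter) is modest. None of them adds fluorine to a ring already carrying it, so the evidence is indirect. A small move towards a lower number in this assay is therefore expected, estimated as a 1.8-fold lower number from compound 3 to compound 4 (0.25 log units; within the scatter). For compound 4 the estimated value is 8000 nM, with an expected range of 2500 nM to 20000 nM.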

Compound 4, half-maximal inhibitory concentration: 16700 nM
Compound 4: middle estimate off by 2.1-fold (0.32 log units), on the low side; measured number inside the range.
By their numbers in this assay, from the lowest: compounds 2, 3, 4 and 1 (each within the scatter of the next, the first and the last beyond it).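

In this assay the move to 2,4,5-trifluorophenyl gives a 1.2-fold higher number from compound 3 to compound 4 (0.07 log units; within the scatter) and the other two comparisons give a 1.4-fold higher number from compound 2 to compound 4 (0.14 log units; within the scatter) and a 1.7-fold lower number from compound 1 to compound 4 (0.22 log units; within the scatter) as well. Compound 4 thus stands within the scatter of all three earlier compounds, even though compound 1 and compound 2 lie beyond the scatter of each other, and adding fluorine to a ring already carrying it does not separate compound 4 from compound 3. No measurement available here accounts for this result. From the compounds shown here alone, whether an amine or a carboxylic acid on this ring would move the number beyond the scatter remains open.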